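The source may hold more compounds than are shown below. What is called first, only, known or untested is meant among the compounds shown, and "the series" means these compounds.

Working notes on the series. In an ADME assay on HEK293 cells (Homo sapiens) for cytotoxicity, read by resazurin assay, with a stated time of 48 h (on this read-out higher numbers stand for lower toxicity in this test and lower numbers for higher toxicity in this test), compound 1 `O=S(=O)(Nc1ccc(-c2nc3ccccc3o2)cc1)c1cccc(F)c1` gives > 100000 nM, which is a limit of the assay rather than a number. Going by the values given here, compound 2 `O=S(=O)(Nc1ccc2oc(-c3ccccc3)nc2c1)c1cccc(Cl)c1` gives 70000 nM in this assay, the only numerical value recorded so far. Among the compounds with values here, the one further value recorded sits at the limit of > 100000 nM in this assay, at which 1 of the 2 values shown sits, and belongs to compound 1. Compound 3 `Cc1cccc(S(=O)(=O)Nc2ccc3oc(-c4ccccc4)nc3c2)c1` has not yet been measured in this assay. It differs from compound 2 by methyl in place of chloro on an aromatic carbon. Within the data shown here, no step between measured compounds has been computed; compound 1 and compound 2 differ in more than one place, and their two values show only that one is a limit and the other a number. For compound 3 the expected step in this assay is a 1.1-fold higher number from compound 2 to compound 3 (0.06 log units; within the scatter), meaning no change beyond the usual scatter. Compound 3 is accordingly estimated at 80000 nM in this assay, with a range from 35000 nM to 160000 nM, and a fair chance that only a limit is reported.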

Compound 3, half-maximal cytotoxic concentration: 69000 nM
Compound 3: middle estimate off by 1.2-fold (0.06 log units), on the high side, and the stated range covers the measured number.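

In this assay, methyl in place of chloro gives a 1.0-fold lower number from compound 2 to compound 3 (0.01 log units; within the scatter), so at this aromatic carbon, meta to a large group, the two groups cannot be told apart in this read-out. Going by these compounds alone, this is the first step between measured compounds that differ in one place, and it shows that 3-chlorophenyl and 3-methylphenyl read alike on the shared core of compound 2 and compound 3. Nothing measured here bears on why the two groups read alike.

The compounds shown leave open whether an amine, a carboxylic acid or a longer chain at this position would also read alike in this assay. Compound 1 differs from compound 2 in more than one place and its entry is a limit, so it does not settle how the rest of the structure contributes.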